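Compound 4: a longer side chain on the methylated series

The compounds below may be only part of what the source reports. "The series", "measured", "known", "first", "only" and "open" are said of these compounds alone.

Measured in a functional assay on HL-60 cells (Homo sapiens) for antiproliferative activity, read by MTT assay, with a stated time of 48 h; a lower number here means a stronger inhibitor, a higher number a weaker inhibitor:
- compound 1 `CN(C)CCn1c(N)c(-c2nc3ccccc3[nH]2)c2nc(C#N)c(C#N)nc21`: 2220 nM
- compound 2 `N#Cc1nc2c(-c3nc4ccccc4[nH]3)c(N)n(CCCN3CCCCC3)c2nc1C#N`: 1680 nM
- compound 3 `CN(C)CCn1c(N)c(-c2nc3ccccc3n2C)c2nc(C#N)c(C#N)nc21`: > 50000 nM

Compound 3 stands at the limit of > 50000 nM in this assay, at which 1 of the 3 values shown sits, which is a limit and not a number.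

Compound 4 `CCN(CC)CCCCn1c(N)c(-c2nc3ccccc3n2C)c2nc(C#N)c(C#N)nc21` keeps the methyl on the aromatic nitrogen of compound 3 and differs on the chain: 2-(diethylamino)ethyl in place of dimethylamino on a saturated chain carbon, two bonds along the chain from an aromatic nitrogen.

Among the compounds with values here, two measured steps bear on this. A chain change gave a 1.3-fold lower number from compound 1 to compound 2 (0.12 log units; within the scatter), while methyl in place of hydrogen on an aromatic nitrogen gave an at least 22-fold higher number from compound 1 to compound 3 (1.35 log units; beyond the scatter). The methyl stays in compound 4, and the chain step from compound 1 suggests little effect, so no step beyond the scatter is expected in this assay.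

The expected change is a number no higher from compound 3 to compound 4 (the limit leaves the size open).

The estimate for compound 4 is 50000 nM, with an expected range of 20000 nM to 100000 nM.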

Compound 4, half-maximal inhibitory concentration: 700 nM
For compound 4 the middle estimate is 71-fold (1.85 log units) above the measured one, and the stated range ends above it.
By their numbers in this assay, from the lowest: compound 4; then compounds 2 and 1 (each within the scatter of the next). At a limit, above all of these: compound 3.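

In this assay, the place on a saturated chain carbon, two bonds along the chain from an aromatic nitrogen, proves decisive once that methyl is present: 2-(diethylamino)ethyl in place of dimethylamino gives an at least 71-fold lower number from compound 3 to compound 4 (1.85 log units; beyond the scatter). With hydrogen on the aromatic nitrogen, a different change at this place gave a 1.3-fold lower number from compound 1 to compound 2 (0.12 log units; within the scatter). The value of compound 3 is a limit: the limit of > 50000 nM in this assay, at which 1 of the 4 values shown sits.

Open, from the compounds shown here alone, is whether the gain follows the longer chain or the ethyl groups on the amine; a 4-(dimethylamino)butyl chain on the methylated core would separate the two. Also open, going by these compounds, is how the 4-(diethylamino)butyl chain behaves with hydrogen on the aromatic nitrogen.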